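Extending the Butoxy Chain: Working Notes on Compound 4

A few compounds are considered here, and "the series" means these few. Any claim that something is new, unique, unknown or untested is made for them only; others in the source may bear on it.

Measured so far in a physicochemical assay for lipophilicity, in phosphate buffer, measured as octanol-water partition, at pH 11.5 (a higher number here means a more lipophilic compound, a lower number a more polar compound), for this series:

- compound 1 `CCCCOC(=N)NC(=N)Nc1ccc(Cl)cc1` gives 3.32
- compound 2 `N=C(NCCCCCCNC(=N)NC(=N)Nc1cccc(C(F)(F)F)c1)NC(=N)Nc1cccc(C(F)(F)F)c1` gives 5.12
- compound 3 `CCCNC(=N)NC(=N)Nc1ccc(Cl)cc1` gives 2.63

Compound 1 stands second highest of the three, with compound 3 lower and compound 2 higher. Compound 4 `CCCCCCOC(=N)NC(=N)Nc1ccc(Cl)cc1` is not yet measured. Relative to compound 1 the change is ethyl in place of hydrogen on a saturated chain carbon, four bonds along the chain from an oxygen on an unsaturated carbon and, cut one bond further out, the same difference reads ethyl to butyl. Within the data shown here, the one measured step at this place, propylamino in place of butoxy, gives a number 0.69 log units lower from compound 1 to compound 3 (beyond the scatter) and is the only guide to size. Among the measured compounds shown here, that step alters more than chain length, so it bears only indirectly, and no measured pair shows a chain lengthened alone. Compound 2 at 5.12 shows that numbers well past that of compound 1 occur in this set, although its structure is far from the others. A rise in this assay is therefore expected, comparable to that measured step or somewhat larger. The step expected is a number 0.98 log units higher from compound 1 to compound 4 (beyond the scatter) on this reasoning. For compound 4 the estimated value is 4.3 with an expected range from 3.8 to 4.8 pending measurement.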

Compound 4, partition coefficient: 4.32
For compound 4 the middle estimate is 0.02 log units below the measured one; the measured number falls inside the stated range.
By their numbers in this assay, from the lowest: compound 3; then compound 1; then compound 4; then compound 2.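

In this assay ethyl in place of hydrogen on a saturated chain carbon, four bonds along the chain from an oxygen on an unsaturated carbon, gives a number 1.00 log units higher from compound 1 to compound 4 (beyond the scatter) as the first measured case in this series of the butoxy chain lengthened with nothing else changed. Set beside a number 0.69 log units lower from compound 1 to compound 3 (beyond the scatter) in the same assay, a step that runs the other way and alters more than chain length, this pair reads chain length alone at this place and shows that the position takes the added carbons with a rise in the number. No independent measurement in the material at hand accounts for the size of this step.

Only one lengthening is shown, so it stays open whether a longer chain than that of compound 4 would continue the rise at a similar size, and whether a branched chain or a chain ending in a hydroxyl group or an amine would follow it. As far as these compounds go, it also stays open whether the same ethyl extension on the propylamino chain of compound 3 would give a step of like size and direction.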